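Trading trifluoromethyl for methoxy in a rat exposure series

The source may report more compounds than this note shows. Statements on the series, on what has been measured and on what is new or still open speak of the compounds shown alone.

In an in vivo ADME assay on the whole organism for pharmacokinetics, with Rattus norvegicus as the target, at a dose of 10 mg/kg by the oral route (a lower number here means less compound in the circulation, a higher number more compound in the circulation at the dose given), compound 1 (`CC1(COc2c(N3CCN(S(=O)(=O)Cc4ccc(N)cc4)CC3)cnn(-c3cccc(Cl)c3)c2=O)CC1`) gives 3490 nM. Among the measured compounds shown here, compound 2 (`CC1(COc2c(N3CCN(S(=O)(=O)Cc4ccc(N)c(C(F)(F)F)c4)CC3)cnn(-c3cccc(Cl)c3)c2=O)CC1`) gives 719 nM, the lower of the two numbers measured so far. Compound 3 (`COc1cc(CS(=O)(=O)N2CCN(c3cnn(-c4cccc(Cl)c4)c(=O)c3OCC3(C)CC3)CC2)ccc1N`) has not yet been measured. It carries methoxy in place of trifluoromethyl on an aromatic carbon, ortho to an amino group: methoxy in place of trifluoromethyl on an aromatic carbon.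

For the measured compounds named here, only one measured step bears on this change: a 4.9-fold lower number from compound 1 to compound 2 (0.69 log units; beyond the scatter), where trifluoromethyl took the place of hydrogen. That step was modest. Going by the values given here, no measured compound carries methoxy, so the guide is loose. With trifluoromethyl gone, a partial return towards compound 1 at 3490 nM is expected, not a full one. The expected step is a 2.2-fold higher number from compound 2 to compound 3 (0.35 log units; beyond the scatter), towards more compound in the circulation. For compound 3, the estimate in this assay is 1600 nM, with an expected range of 550 nM to 4500 nM.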

Compound 3, maximal plasma concentration: 5750 nM
Compound 3: the middle estimate sits 3.6-fold (0.56 log units) below what was measured; the whole stated range lies below it.
By their numbers in this assay, from the lowest: compound 2; then compounds 1 and 3 (each within the scatter of the next).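

In this assay, what matters at this position is which group sits there, not only whether the hydrogen is replaced: methoxy in place of trifluoromethyl gives an 8.0-fold higher number from compound 2 to compound 3 (0.90 log units; beyond the scatter) in this series. Methoxy in place of hydrogen gives a 1.6-fold higher number from compound 1 to compound 3 (0.22 log units; within the scatter) and stays within the scatter, so methoxy and hydrogen cannot be told apart here. Of the three groups shown at this carbon, only trifluoromethyl stands apart, with the lowest number. Nothing measured here explains why these groups differ.

As far as these compounds go, whether fluorine, chlorine or a longer ether such as ethoxy at this same carbon would read like methoxy or like trifluoromethyl stays open. So does whether methoxy would behave the same way if an acetamide took the place of the amino group.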